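A few compounds are considered here, and "the series" means these few. Any claim that something is new, unique, unknown or untested is made for them only; others in the source may bear on it.

Compound 1 `COc1ccc(-c2nc(-c3ccccc3)c(-c3ccc4c(c3)NC(=O)CO4)[nH]2)cc1` gives the lowest number of the three in a functional assay on A549 cells (Homo sapiens) for cytotoxicity, read by colorimetric assay and MTT assay, with a stated time of 3 days, tested at 20 uM (on this read-out lower numbers stand for a stronger effect and higher numbers for a weaker effect at the one concentration tested), at 38.1%; both of its steps to the other compounds are beyond the scatter, so it is the strongest of the set. Compound 2 `O=C1COc2ccc(-c3nn(-c4ccc(F)cc4)cc3-c3ccccc3)cc2N1` gives 56.4% in this assay, and compound 3 `O=C1COc2ccc(-c3nn(-c4cc(Cl)cc(Cl)c4)cc3-c3ccccc3)cc2N1` gives 70.2%. For the measured compounds named here, the only measured step, a number 13.8 percentage points higher from compound 2 to compound 3 (beyond the scatter), concerns a substituent on an aromatic nitrogen and does not bear on the change to compound 4 `O=C1COc2ccc(-c3[nH]c(-c4ccccc4)nc3-c3ccccc3)cc2N1`, which is hydrogen in place of methoxy on an aromatic carbon. Going by the values given here, no measured pair shows what this change does, so the step is expected to stay small, a number 6.9 percentage points higher from compound 1 to compound 4 (within the scatter), with some drift upward allowed. Compound 4 is estimated at 45%, range 30% to 62%.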

Compound 4, a percentage reported as activity, at one concentration (the size of the read-out at that concentration, not a potency): 58.5%
Compound 4: the middle estimate sits 13.5 percentage points below what was measured; the range from low to high includes it.
By their numbers in this assay, from the lowest: compound 1; then compounds 2 and 4 (each within the scatter of the next); then compound 3.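

In this assay, the change from 4-methoxyphenyl to phenyl gives a number 20.4 percentage points higher from compound 1 to compound 4 (beyond the scatter) and so links the methoxy, para to a large group, to the stronger effect within this pair. For the compounds shown here, this is the first sign that the series responds to what this position carries, though it rests on one pair. Nothing available gives a measured reason for the step.

On these data alone, whether an amine, a hydroxyl or a longer chain such as ethoxy at this place would match or exceed methoxy remains open.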